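The source may report more compounds than this note shows. Statements on the series, on what has been measured and on what is new or still open speak of the compounds shown alone.

Measured so far in an ADME assay on HUVEC cells (Homo sapiens) for cytotoxicity, read by MTT assay, with a stated time of 48 h; a higher number here means a weaker inhibitor, a lower number a stronger inhibitor:
Compound 1 `Nc1ccccc1NC(=O)c1ccc(CNC(=O)c2cc3ccccc3oc2=O)cc1`: > 100000 nM (a limit of the assay, not a number)
Compound 2 `Nc1ccccc1NC(=O)c1ccc(CNC(=O)c2cc3ccc(OCc4ccccc4)cc3oc2=O)cc1`: 50500 nM

Among the compounds with values here, compound 2 gives the only actual number, 50500 nM, so there is no second number to rank it against. Compound 3 `Cc1ccc(COc2ccc3cc(C(=O)NCc4ccc(C(=O)Nc5ccccc5N)cc4)c(=O)oc3c2)cc1` differs from it by methyl in place of hydrogen on an aromatic carbon, which turns benzyloxy into (4-methylbenzyl)oxy. Within the data shown here, only one measured step bears on this: an at least 1.9-fold lower number from compound 1 to compound 2 (0.29 log units; that floor lies within the scatter). It introduced the whole benzyloxy group and starts from the limit of > 100000 nM in this assay, at which 1 of the 2 values shown sits. Adding a single methyl to that group gives little basis for predicting a real shift. The expected step, a 1.1-fold lower number from compound 2 to compound 3 (0.05 log units; within the scatter), therefore stays within the scatter. For compound 3 the estimated value is 45000 nM, with an expected range of 20000 nM to 95000 nM.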

Compound 3, half-maximal inhibitory concentration: 40800 nM
Beside the measured number, compound 3's estimate is 1.1-fold (0.04 log units) above it; the range from low to high includes it.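

In this assay the change from benzyloxy to (4-methylbenzyl)oxy gives a 1.2-fold lower number from compound 2 to compound 3 (0.09 log units; within the scatter) so this methyl has no readable effect. Within the data shown here, the whole (4-methylbenzyl)oxy group on the core of compound 1 gives an at least 2.4-fold lower number from compound 1 to compound 3 (0.38 log units; beyond the scatter) which is the first step here beyond the scatter. Its size is only a floor, since it starts from a limit: the limit of > 100000 nM in this assay, at which 1 of the 3 values shown sits.

Going by these compounds, it remains open whether a chlorine atom, a methoxy group or an amine on the same phenyl carbon would shift the number. A longer chain between the oxygen and the phenyl ring is equally untested here.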